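Sulfonate-bearing acrylamides: methoxy for methyl on the sulfonyl aryl

A few compounds are considered here, and "the series" means these few. Any claim that something is new, unique, unknown or untested is made for them only; others in the source may bear on it.

Compound 1 `Cc1ccc(S(=O)(=O)Oc2ccccc2/C=C(\C#N)C(=O)Nc2nnc(Cc3ccc(F)cc3)s2)cc1` is the reference of this small set. In a functional assay on RS4-11 cells (Homo sapiens) for inhibition, read by CCK-8 assay, with a stated time of 48 h, tested at 20 uM (a lower number here means less inhibition of growth, a higher number more inhibition of growth at the concentration tested), compound 1 gives 72%. Compound 2 `COc1ccc(S(=O)(=O)Oc2ccccc2/C=C(\C#N)C(=O)Nc2nnc(Cc3ccc(F)cc3)s2)cc1` carries the change (methoxy in place of methyl on an aromatic carbon); its value in this assay is 76%, and the step is a number 4 percentage points higher from compound 1 to compound 2 (within the scatter). Compound 3 `Cc1ccc(Cc2nnc(NC(=O)/C(C#N)=C/c3ccccc3OS(=O)(=O)c3ccc(C)cc3)s2)cc1` differs from compound 1 in the core by methyl in place of fluoro on an aromatic carbon; in this assay compound 3 gives 66%, with the step of a number 6 percentage points lower from compound 1 to compound 3 (within the scatter).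

Compound 4 `COc1ccc(S(=O)(=O)Oc2ccccc2/C=C(\C#N)C(=O)Nc2nnc(Cc3ccc(C)cc3)s2)cc1` has not been measured. It differs from compound 3 by methoxy in place of methyl on an aromatic carbon, the same change that leads from compound 1 to compound 2, made on the same place and now on the core of compound 3. The step from compound 3 to compound 4 is expected to be a number 4 percentage points higher from compound 3 to compound 4 (within the scatter), small like the earlier one, because the earlier step of a number 4 percentage points higher from compound 1 to compound 2 (within the scatter) stayed within the scatter. The estimate for compound 4 in this assay is 70%, expected to fall between 58% and 82%.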

Compound 4, percent growth inhibition at one concentration: 79%
Beside the measured number, compound 4's estimate is 9 percentage points below it; the range from low to high includes it.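

In this assay, 4-methylphenyl to 4-methoxyphenyl on the sulfonyl side gives a number 13 percentage points higher from compound 3 to compound 4 (beyond the scatter), and this step does not differ from the one on the core of compound 1: the same change on two cores in this assay, a number 4 percentage points higher (within the scatter) from compound 1 to compound 2 and a number 13 percentage points higher (beyond the scatter) from compound 3 to compound 4, 9 percentage points apart, within the scatter of two such steps. Methyl in place of fluoro, read on the methoxy-bearing core, gives a number 3 percentage points higher from compound 2 to compound 4 (within the scatter), and it too does not differ from its counterpart: the same change on two cores in this assay, a number 6 percentage points lower (within the scatter) from compound 1 to compound 3 and a number 3 percentage points higher (within the scatter) from compound 2 to compound 4, 9 percentage points apart, within the scatter of two such steps. Among the compounds shown here, the methoxy change thus carries across these two cores with no detectable difference between its steps, but only one of those steps lies beyond the scatter, so two cores fix neither a size for the step nor a rule for the series.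

Still open, as far as these compounds go, is whether a longer chain such as ethoxy, or an amine, in the place of the methoxy on the sulfonyl aryl would give a comparable number. Also open, from the compounds shown here alone, is whether the step would hold on a core with chloro in place of the fluoro or methyl.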